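The compounds below may be only part of what the source reports. "The series", "measured", "known", "first", "only" and "open" are said of these compounds alone.

For the measured compounds named here, in a functional assay on MCF7 cells (Homo sapiens) for inhibition, read by colorimetric assay and MTT assay, with a stated time of 72 h (a lower number here means a stronger inhibitor, a higher number a weaker inhibitor), compound 3 (`C=CCCCCOc1ncc(-c2ccccc2OC)n1C`) gives 5000 nM, level with compound 1 (`C=CCCCCOc1ccccc1-c1cnc(OCCCCC=C)n1C`) at 5000 nM, and the two share the lowest number of the three measured so far. Compound 2 (`CCCCOc1ncc(-c2ccccc2OC)n1C`) stands apart at 55000 nM.

The next compound, compound 4 (`C=CCCCCOc1ncc(-c2ccc(Cl)cc2OC)n1C`), differs from compound 3 by chloro in place of hydrogen on an aromatic carbon, meta to a methoxy group and para to a large group: chloro in place of hydrogen on an aromatic carbon.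

Going by the values given here, no measured step makes this swap, so the data offer only indirect guidance. Vinyl in place of hydrogen on the saturated chain gave an 11-fold lower number from compound 2 to compound 3 (1.04 log units; beyond the scatter), a large step, but that change lies on the chain. The change at a group on the same aromatic ring gave no change at the digits printed from compound 1 to compound 3 (within the scatter), and this is the more relevant guide, so only a small shift is expected. The expected step is a 1.3-fold lower number from compound 3 to compound 4 (0.10 log units; within the scatter), which would stay within the scatter. For compound 4 the estimate is 4000 nM, with an expected range from 1300 nM to 12000 nM.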

Compound 4, half-maximal inhibitory concentration: 37000 nM
The estimate for compound 4 lay 9.3-fold (0.97 log units) below the measured number; measured number above the stated range.
By their numbers in this assay, from the lowest: compounds 1 and 3 (each within the scatter of the next); then compounds 4 and 2 (each within the scatter of the next).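

In this assay, chloro in place of hydrogen on the aromatic carbon meta to a methoxy group and para to a large group gives a 7.4-fold higher number from compound 3 to compound 4 (0.87 log units; beyond the scatter). This ring is therefore not indifferent to every change, as the earlier change on it, with no change at the digits printed from compound 1 to compound 3 (within the scatter), might have suggested: one added chlorine atom at this carbon is enough to weaken inhibition clearly. Nothing available explains why this chlorine has that effect.

The compounds shown leave open whether the loss belongs to chloro in particular or would follow any group placed on this carbon. A fluoro, a methyl or an amine at the same carbon would help separate those two readings, and the same chloro at another carbon of the ring would show how specific the effect is to this position.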